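The source may report more compounds than this note shows. Statements on the series, on what has been measured and on what is new or still open speak of the compounds shown alone.

Compound 1 `C=C1[C@H](OC(C)=O)[C@H]2[C@@H](OC(C)=O)[C@@H](C)C[C@]2(OC(C)=O)C(=O)[C@@H](C)/C=C/C(C)(C)C(=O)[C@H](OC(C)=O)[C@H]1OC(=O)C(C)C` is one of three compounds tested in an ADME assay on MCF7 cells (Homo sapiens) for cytotoxicity, read by MTT assay, with a stated time of 48 h; on this read-out lower numbers stand for stronger inhibition and higher numbers for weaker inhibition. In this assay compound 1 gives only > 100000 nM, which is a limit of the assay rather than a number. Compound 2 `C=C1[C@H](OC(=O)C(C)C)[C@@H](OC(C)=O)[C@@H](OC(C)=O)C(C)(C)/C=C/[C@H](C)C(=O)[C@@]2(O)C[C@@](C)(OC(C)=O)[C@H](OC(C)=O)[C@@H]2[C@H]1OC(=O)c1ccccc1` likewise gives a limit, > 100000 nM. Compound 3 `C=C1CCC(=O)C(C)(C)/C=C/[C@H](C)C(=O)[C@@]2(OC(C)=O)C[C@H](C)[C@H](O)[C@@H]2[C@H]1OC(=O)c1ccccc1` gives 70900 nM. Across the three, (the limit of > 100000 nM in this assay, at which 2 of the 3 values shown sit), so no measured step between compounds is available to lean on.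

Compound 4 `C=C1[C@H](OC(C)=O)[C@H]2[C@@H](OC(C)=O)[C@@H](C)C[C@]2(OC(C)=O)C(=O)[C@@H](C)/C=C/C(C)(C)C(=O)[C@H](OC(C)=O)[C@H]1OC(=O)CC` differs from compound 1 by hydrogen in place of methyl on a saturated chain carbon bound to a carbonyl carbon and a saturated chain carbon, a change of one heavy atom at the isopropylcarbonyl ester. Within the data shown here, with no measured step to go by, the expected step of a number no higher from compound 1 to compound 4 (the limit leaves the size open) is none beyond the usual scatter. Compound 4 is therefore expected near 100000 nM, within 40000 nM to 250000 nM, and most probably again reported only as a limit.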

Compound 4, half-maximal inhibitory concentration: > 100000 nM
Compound 4 gave a limit, no number; the forecaster's own chance of this, stated with the estimate: 70%; the middle value lies on the limit itself.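

Compound 1 and compound 4 both sit at a limit of this assay, not at a number, so no step between them can be read: the limit of > 100000 nM in this assay, at which 3 of the 4 values shown sit.

The compounds shown leave open whether going from isopropylcarbonyl to propanoyl changes the cytotoxicity at all.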